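Extending the Allyl Chain of a Shared Core

The source may report more compounds than this note shows. Statements on the series, on what has been measured and on what is new or still open speak of the compounds shown alone.

Among the compounds with values here, compound 1 `C=CCC(O)(c1ccc(OC)c(OC)c1OC)c1cccc2ccccc12` is the first of two measured compounds built on a shared core. In a functional assay on A549 cells (Homo sapiens) for inhibition, read by sulforhodamine B assay, with a stated time of 48 h (a higher number here means a weaker inhibitor, a lower number a stronger inhibitor), compound 1 gives 10700 nM. Compound 2 `COc1ccc(/C(=C/c2ccc(F)cc2)c2cccc3ccccc23)c(OC)c1OC` keeps the same core, and in this assay compound 2 gives 18600 nM. These two numbers lie within the scatter of each other, so compound 1 holds the lower of the two numbers without standing apart from compound 2. Compound 3 `COc1ccc(C(O)(C/C=C\c2ccccc2)c2cccc3ccccc23)c(OC)c1OC` has not yet been measured. It differs from compound 1 in one place: 2-phenylethenyl in place of vinyl on a saturated chain carbon, two bonds along the chain from two aromatic carbons and an oxygen on a saturated carbon. Within the data shown here, no step between measured compounds mirrors this change, so nothing in the numbers so far points in either direction. The expected step, a 1.3-fold lower number from compound 1 to compound 3 (0.13 log units; within the scatter), is therefore small, not clearly beyond the scatter either way. For compound 3 the value expected in this assay is 8000 nM, with a range from 2500 nM to 25000 nM.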

Compound 3, half-maximal inhibitory concentration: 17600 nM
Compound 3: middle estimate off by 2.2-fold (0.34 log units), on the low side; the measured number falls inside the stated range.
By their numbers in this assay, from the lowest: compounds 1, 3 and 2 (each within the scatter of the next).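

In this assay, the first step read at this position, 2-phenylethenyl in place of vinyl on a saturated chain carbon, gives a 1.6-fold higher number from compound 1 to compound 3 (0.22 log units; within the scatter). The same difference, cut one bond further out, reads allyl to 3-phenylprop-2-en-1-yl, so this position carries a group of 8 heavy atoms with a six-membered aromatic ring of carbon only, where vinyl has 2 heavy atoms and no ring, and the two numbers still cannot be told apart. This single step shows that tolerance for this one change, and no trend along a series.

The compounds shown leave open how an amine or a carboxylic acid in place of the vinyl would read in this assay. They also leave open whether a 2-phenylethenyl carrying a methoxy group would stay within the scatter of compound 1. No measurement offered here bears on why the two numbers lie so close.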